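The source may hold more compounds than are shown below. What is called first, only, known or untested is meant among the compounds shown, and "the series" means these compounds.

Measured in a physicochemical assay for solubility, read by spectrophotometry, in phosphate buffer, with a stated time of 18 h, at pH 7.4 (a higher number here means a more soluble compound, a lower number a less soluble compound), so far:
compound 1 `CCc1ccc(-c2nc3c(c(C)nn3-c3ccccc3)c(-c3ccccc3O)c2C#N)cc1` gives 3100 nM
compound 2 `Cc1ccccc1-c1nc2c(c(C)nn2-c2ccccc2)c(-c2ccccc2O)c1C#N` gives 21000 nM
compound 3 `Cc1nn(-c2ccccc2)c2nc(-c3ccc(C(F)(F)F)cc3)c(C#N)c(-c3ccccc3O)c12` gives 3500 nM

Compound 3 lies within the scatter of compound 1 and well under compound 2, with a 6.0-fold lower number from compound 2 to compound 3 (0.78 log units; beyond the scatter) on record. The change to compound 4 `Cc1nn(-c2ccccc2)c2nc(-c3ccc4c(c3)CCCC4)c(C#N)c(-c3ccccc3O)c12` is 1,2,3,4-tetrahydronaphthalen-6-yl in place of 4-(trifluoromethyl)phenyl on an aromatic carbon on the shared core. The nearest guide is a 1.1-fold higher number from compound 1 to compound 3 (0.05 log units; within the scatter) for trifluoromethyl in place of ethyl. The larger steps, a 6.8-fold higher number from compound 1 to compound 2 (0.83 log units; beyond the scatter) and a 6.0-fold lower number from compound 2 to compound 3 (0.78 log units; beyond the scatter), both involve the 2-methylphenyl of compound 2, a group compound 4 lacks. No step beyond the scatter is therefore expected in this assay here. The expected step is a 1.2-fold lower number from compound 3 to compound 4 (0.07 log units; within the scatter) or thereabouts. Compound 4 is estimated at 3000 nM within 1100 nM to 8000 nM as the expected range.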

Compound 4, solubility: 13000 nM
Estimate against measurement, compound 4: 4.3-fold (0.64 log units) below; the whole stated range lies below it.
By their numbers in this assay, from the lowest: compounds 1 and 3 (each within the scatter of the next); then compounds 4 and 2 (each within the scatter of the next).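

In this assay, a step beyond the scatter at this position, next to the ring nitrogen, does not depend on the 2-methylphenyl group: 1,2,3,4-tetrahydronaphthalen-6-yl also gives one (a 3.7-fold higher number from compound 3 to compound 4 (0.57 log units; beyond the scatter); a 4.2-fold higher number from compound 1 to compound 4 (0.62 log units; beyond the scatter)). It stands within the scatter of the 2-methylphenyl group (a 1.6-fold lower number from compound 2 to compound 4 (0.21 log units; within the scatter)), so two differently shaped carbon-only aryl groups share the upper band. No measured property bears on these steps.

On these data alone, whether an amine or a carboxylic acid on this aryl ring would shift the number remains open. So does the effect of a longer chain in place of the six-membered non-aromatic ring.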